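This account rests on a few compounds, and the source may have more. Where it says the series, first, only, none or still open, it means among the compounds named here.

Among the compounds with values here, compound 1, `COC(=O)c1c(F)cccc1OC(=O)COc1cc(O)c2c(=O)cc(-c3ccccc3)oc2c1`, is one of only two compounds measured so far in a functional assay on cells (T-cell, Mus musculus, strain BALB/c) for inhibition, read by MTT assay, with a stated time of 72 h (a lower number here means a stronger inhibitor, a higher number a weaker inhibitor), where compound 1 gives 40300 nM. The other, compound 2, `COC(=O)c1c(C)cccc1OC(=O)COc1cc(O)c2c(=O)cc(-c3ccccc3)oc2c1`, gives 37200 nM in this assay, and the change a 1.1-fold lower number from compound 1 to compound 2 (0.03 log units; within the scatter) shows the two numbers sit within the scatter of each other. Compound 3, `COC(=O)c1cc(Br)ccc1OC(=O)COc1cc(O)c2c(=O)cc(-c3ccccc3)oc2c1`, carries 4-bromo-2-(methoxycarbonyl)phenyl in place of 3-fluoro-2-(methoxycarbonyl)phenyl on an oxygen next to a carbonyl group. Within the data shown here, the only measured step also swaps a group on that same aromatic ring and moved the number hardly at all, so no step beyond the scatter is expected here. For compound 3 the estimated value is 38000 nM, with a range from 15000 nM to 95000 nM. This estimate means an expected step of a 1.1-fold lower number from compound 1 to compound 3 (0.03 log units; within the scatter).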

Compound 3, half-maximal inhibitory concentration: 780 nM
Compound 3: the middle estimate sits 49-fold (1.69 log units) above what was measured, outside the stated range (below it).
By their numbers in this assay, from the lowest: compound 3; then compounds 2 and 1 (each within the scatter of the next).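

Swapping a group on this ring had moved the number by no more than the scatter, but this change gives a 52-fold lower number from compound 1 to compound 3 (1.71 log units; beyond the scatter) and also a 48-fold lower number from compound 2 to compound 3 (1.68 log units; beyond the scatter) in this assay as the result. The group on an oxygen next to a carbonyl group is therefore not indifferent to change: the number can move sharply with the groups on this ring. No measurement shown explains the drop. Still open, as far as these compounds go, is whether the bromine or its place on the ring matters more, since one change alters both. A chloro or methoxy group in place of the bromine could begin to separate these.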